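Lengthening the Ethyl Chain of Compound 2

The source may hold more compounds than are shown below. What is called first, only, known or untested is meant among the compounds shown, and "the series" means these compounds.

In a functional assay on the whole organism (blood, strain albino) with Mus musculus as the target, with stated times of 6 days and 3 h, at a dose of 1 mmol/kg by the oral route (a lower number here means less inhibition, a higher number more inhibition at the dose given (going by the name of the read-out)), compound 1, `CCN1C(=O)CCN(S(=O)(=O)c2ccc(-n3nc(C)cc3C)cc2)C1=S`, gives 4%.
Compound 2, `CCN1C(=O)CCN(S(=O)(=O)c2ccc(-n3nc(C(=O)O)cc3C)cc2)C1=S`, gives 1%.
Compound 3, `Cc1cc(C)n(-c2ccc(S(=O)(=O)N3CCC(=O)N(c4ccccc4)C3=S)cc2)n1`, reaches only the assay limit < 1%.

Compound 2 stands lowest of the two numbers shown, yet the step of a number 3 percentage points lower from compound 1 to compound 2 (within the scatter) lies within the scatter; the third value is a limit (the limit of < 1% in this assay, at which 1 of the 3 values shown sits). Compound 4, `CCCN1C(=O)CCN(S(=O)(=O)c2ccc(-n3nc(C(=O)O)cc3C)cc2)C1=S`, differs from compound 2 by methyl in place of hydrogen on a saturated chain carbon, two bonds along the chain from an amide-type nitrogen in a ring. For the measured compounds named here, no measured step alters this chain: a number 3 percentage points lower from compound 1 to compound 2 (within the scatter) changes a group on an aromatic carbon and a number at least 3 percentage points lower from compound 1 to compound 3 (that floor lies within the scatter) swaps the whole group on the ring nitrogen, and both stayed small. Compound 4 is therefore expected to show no step beyond the scatter, a number 1 percentage points higher from compound 2 to compound 4 (within the scatter). Compound 4 is estimated at 2%, within 0% to 9%.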

Compound 4, a percentage reported as inhibition, in the whole organism at one dose (the size of the read-out at that dose, not a potency): < 1%
Compound 4: no number, only a limit (the forecaster's own chance of this, stated with the estimate: 35%); middle value at least 1 percentage points away from the limit.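

Lengthening the ethyl chain to propyl, with methyl in place of hydrogen on a saturated chain carbon, gives a number no higher from compound 2 to compound 4 (the limit leaves the size open) in this assay, so this is the first look at the chain length itself. Compound 4 gives < 1%, which is a limit of the assay and not a number. This one added carbon therefore brings no readable gain, and the compounds now gather at the bottom of the scale: the limit of < 1% in this assay, at which 2 of the 4 values shown sit.

From the compounds shown here alone, whether a longer chain, or an amine on this chain, would lift the read-out clear of that limit stays open.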